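Cytotoxicity notes: methyl added to the chain of compound 1

The compounds below may be only part of what the source reports. "The series", "measured", "known", "first", "only" and "open" are said of these compounds alone.

Measured so far:
compound 1 `CCCCCCCc1cc2cn(COCCO)c(=O)nc2o1` — 400000 nM
compound 2 `CCCCCCc1cc2cn(COCCO)c(O)nc-2n1` — > 400000 nM
compound 3 `O=c1nc2occc2cn1COCCO` — > 400000 nM

Among the compounds with values here, in a functional assay on HEL cells (Homo sapiens), read by microscopy (a lower number here means that less compound is tolerated, a higher number that more compound is tolerated), compound 1 gives 400000 nM, the only number among the three values shown. The value of compound 2 in this assay is a limit of the assay, not a number. The value of compound 3 in this assay is likewise a limit. Within the data shown here, the single step between compounds that differ in one place, a number no lower from compound 1 to compound 3 (the limit leaves the size open), hydrogen in place of heptyl on an aromatic carbon, runs into that limit and so its size cannot be read.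

Compound 4 `CCCCCCCCc1cc2cn(COCCO)c(=O)nc2o1` differs from compound 1 by methyl in place of hydrogen on a saturated chain carbon, seven bonds along the chain from an aromatic carbon. Among the measured compounds shown here, no measured step bears directly on this change: the one step known removes the whole chain in the other direction and ends at a limit. Given (the limit of > 400000 nM in this assay, at which 2 of the 3 values shown sit), little room for separation remains above compound 1, and the data show no step at all that moves beyond the scatter. The step expected from this change is therefore no change at the digits printed from compound 1 to compound 4 (within the scatter), within the scatter. Compound 4 is expected to give 400000 nM, between 200000 nM and 800000 nM, with a real chance that only a limit is reported.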

Compound 4, minimum cytotoxic concentration: >= 80000 nM
Compound 4: only a limit was reported; the forecaster's own chance of this, stated with the estimate: 50%; the middle value lies beyond the limit too.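

In this assay compound 4 gives >= 80000 nM, which is a limit of the assay and not a number, and the step from compound 1 to compound 4 cannot be read. The compounds shown leave open whether methyl in place of hydrogen on this chain shifts the minimum cytotoxic concentration in either direction.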